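Working notes: compound 3 to compound 4 in the series

The source may report more compounds than this note shows. Statements on the series, on what has been measured and on what is new or still open speak of the compounds shown alone.

Measured so far in a functional assay on PC-3 cells (Homo sapiens) for antiproliferative activity, read by MTT assay, with a stated time of 72 h; on this read-out lower numbers stand for stronger inhibition and higher numbers for weaker inhibition:
compound 1 `CCCSc1nc(Cl)c2c(n1)N(CCNC(=O)OC(C)(C)C)C(C(=O)N1CCN(C)CC1)N2`: > 64000 nM
compound 2 `CCCSc1nc(Cl)c2c(n1)N(Cc1cccs1)C(C(=O)N1CCN(C)CC1)N2`: 5020 nM
compound 3 `CCCSc1nc(Cl)c2c(n1)N(Cc1ccco1)C(C(=O)N1CCN(C)CC1)N2`: 11400 nM

The value of compound 1 in this assay is a limit of the assay, not a number, and the only one so far at the limit of > 64000 nM in this assay, at which 1 of the 3 values shown sits. Among the two true numbers, compound 3 stands highest, with compound 2 nearest: a 2.3-fold higher number from compound 2 to compound 3 (0.36 log units; beyond the scatter). Against compound 1 both aromatic five-membered substituents gave clearly lower numbers, an at least 12-fold lower number from compound 1 to compound 2 (1.10 log units; beyond the scatter) and an at least 5.6-fold lower number from compound 1 to compound 3 (0.74 log units; beyond the scatter).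

Compound 4 is `CCCSc1nc(Cl)c2c(n1)N(CC1CCCCC1)C(C(=O)N1CCN(C)CC1)N2` and has not yet been measured. It differs from compound 3 by cyclohexyl in place of furan-2-yl on a saturated chain carbon bound to a nitrogen on an aromatic ring in a ring.

Going by the values given here, no measured step exchanges an aromatic ring for a saturated carbocycle at this position, so the bearing steps are indirect. The step from compound 3 to compound 2 shows that a change among small rings here moves the number modestly, while the steps from compound 1 show that removing the ((tert-butoxycarbonyl)amino)methyl group is where the large movement lay. A modest step, somewhat towards a lower number, is therefore expected: a 1.8-fold lower number from compound 3 to compound 4 (0.24 log units; within the scatter). Compound 4 is estimated at 6500 nM in this assay, with a range from 2000 nM to 22000 nM.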

Compound 4, half-maximal inhibitory concentration: 12800 nM
Compound 4: the middle estimate sits 2.0-fold (0.29 log units) below what was measured; measured number inside the range.
By their numbers in this assay, from the lowest: compound 2; then compounds 3 and 4 (each within the scatter of the next). At a limit, above all of these: compound 1.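

In this assay, cyclohexyl and furan-2-yl on a saturated chain carbon bound to a nitrogen on an aromatic ring in a ring cannot be told apart, a 1.1-fold higher number from compound 3 to compound 4 (0.05 log units; within the scatter), so an aromatic ring is not needed here to reach the level of compound 3. Thiophen-2-yl remains apart from both, with a 2.5-fold higher number from compound 2 to compound 4 (0.41 log units; beyond the scatter), so among the true numbers in this assay the advantage at this place so far belongs to compound 2 alone, and it does not follow a simple aromatic versus saturated divide, as compound 3 goes against one. The step, an at least 5.0-fold lower number from compound 1 to compound 4 (0.69 log units; beyond the scatter), starts from a limit of the assay and not from a number, so it gives only a bound, yet the saturated ring also stays clear of that limit: the limit of > 64000 nM in this assay, at which 1 of the 4 values shown sits.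

The change to cyclohexyl alters ring size and aromatic character together, and phenyl at this place would part the two. Also open, going by these compounds, are how an amine such as piperidin-4-yl or an open alkyl chain such as n-butyl would read, and whether the edge of compound 2 goes with the sulfur atom of its ring.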